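This account rests on a few compounds, and the source may have more. Where it says the series, first, only, none or still open, it means among the compounds named here.

Working notes on the indole series, the shared core of compound 3 `CCOC(=O)C(=O)CC(=O)/C=C/c1cn(-c2ccccc2)c2ccccc12` carried throughout. In an assay on isolated protein for inhibition of DNA nucleotidylexotransferase (Homo sapiens), read by scintillation counting, with a stated time of 10 min (a lower number here means a stronger inhibitor, a higher number a weaker inhibitor), compound 3 gives only a limit, > 40 uM. Compound 1 `CCOC(=O)C(=O)CC(=O)/C=C/c1cn(CCC(C)C)c2ccccc12` in this assay likewise gives only a limit, > 40 uM. Compound 2 `CCOC(=O)C(=O)CC(=O)/C=C/c1cn(C=C(C)C)c2ccccc12` in this assay also gives only a limit, > 40 uM. The steps a step that the two limits leave unreadable from compound 1 to compound 2, a step that the two limits leave unreadable from compound 1 to compound 3 and a step that the two limits leave unreadable from compound 2 to compound 3 therefore cannot be sized; the only fixed point is the limit of > 40 uM in this assay, at which 3 of the 3 values shown sit.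

Compound 4 `CCOC(=O)C(=O)CC(=O)/C=C/c1cn(-c2ccc(Cl)cc2)c2ccccc12` differs from compound 3 by chloro in place of hydrogen on an aromatic carbon. Among the compounds with values here, no measured step reads on this change, and with every value sitting at the limit, compound 4 is expected to remain at or near it: the estimate for compound 4 is 60 uM (20 uM to 200 uM), a step that the limit leaves unreadable from compound 3 to compound 4 from compound 3 to compound 4 expected to be none beyond the scatter.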

Compound 4, concentration for 50% inhibition: > 40 uM
Compound 4: a limit, no number; the forecaster's own chance of this, stated with the estimate: 75%; the middle value is on the limit's open side.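

In this assay, within the data shown here, compound 4 gives only a limit, > 40 uM, and no step from compound 1, compound 2 or compound 3 to compound 4 can be read. Whether any substituent on the aromatic nitrogen gives a measurable inhibition value stays open: the limit of > 40 uM in this assay, at which 4 of the 4 values shown sit.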